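A few compounds are considered here, and "the series" means these few. Any claim that something is new, unique, unknown or untested is made for them only; others in the source may bear on it.

In a physicochemical assay for solubility, read by LC-MS, using the shake flask method, measured as thermodynamic solubility, with a stated time of 24 h, at pH 6.5 (a higher number here means a more soluble compound, a lower number a less soluble compound), the measured compounds stand as follows.
Compound 1 `O=C(O)c1cccc(-n2cc(CO[C@H]3O[C@H](CO)[C@@H](O)[C@H](O)[C@@H]3O)nn2)c1` gives > 3000 ug/mL as a limit.
Compound 2 `O=C(O)c1cncc(-n2cc(CO[C@H]3O[C@H](CO)[C@@H](O)[C@H](O)[C@@H]3O)nn2)c1` gives > 3000 ug/mL as a limit.
Compound 3 `Nc1ccc(-n2cc(CO[C@H]3O[C@H](CO)[C@@H](O)[C@H](O)[C@@H]3O)nn2)cc1` gives > 2000 ug/mL as a limit.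

Compound 3 therefore has no number in the series, only a limit. For compound 3 that is the limit of > 2000 ug/mL in this assay, at which 1 of the 3 values shown sits, in the series. For compound 1 and compound 2 it is the limit of > 3000 ug/mL in this assay, at which 2 of the 3 values shown sit, in the series.

The next compound is compound 4 `COc1ccc(Cn2cc(CO[C@H]3O[C@H](CO)[C@@H](O)[C@H](O)[C@@H]3O)nn2)cc1`, with 4-methoxybenzyl in place of 4-aminophenyl on an aromatic nitrogen of a five-membered aromatic ring with 3 nitrogen. The counted difference is 4-methoxybenzyl in place of 4-aminophenyl on an aromatic nitrogen at that one place.

Three measured steps change the group at this same place: a step that the two limits leave unreadable from compound 1 to compound 3 and a step that the two limits leave unreadable from compound 2 to compound 3 and a step that the two limits leave unreadable from compound 1 to compound 2 on the same nitrogen. None of them has a readable size, so they offer no measured size to carry over. No step beyond the scatter is therefore expected in this assay and no direction is favoured. The expected move is a step that the limit leaves unreadable from compound 3 to compound 4 on this basis. That expectation starts from compound 3 at > 2000 ug/mL as a limit. Another limit is a likely outcome for compound 4. Compound 4 is estimated at 2500 ug/mL with an expected range from 1000 ug/mL to 5000 ug/mL in this reading.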

Compound 4, solubility: > 3000 ug/mL
Compound 4: no number, only a limit (the forecaster's own chance of this, stated with the estimate: 60%); middle value at least 1.2-fold (0.07 log units) away from the limit.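

In this assay compound 4 gives > 3000 ug/mL, a limit. Among these compounds, compound 1, compound 2 and compound 3 also stand only as limits, so no step from any of them to compound 4 can be read. The compounds shown leave open how far apart their solubilities lie, and whether the group on the aromatic nitrogen makes any measurable difference.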